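Iodo for Ethynyl on a Cytotoxicity Core

The compounds below may be only part of what the source reports. "The series", "measured", "known", "first", "only" and "open" are said of these compounds alone.

Four nucleoside-like compounds share a core in which a five-membered aromatic ring with one nitrogen is fused to a second ring, with a sugar attached at the ring nitrogen. Compound 1 has the structure `C#Cc1cn([C@@H]2O[C@H](CO)[C@@H](O)[C@H]2O)c2ncnc(NC)c12` and compound 2 the structure `C#Cc1cn([C@@H]2O[C@H](CO)[C@@H](O)[C@H]2O)c2nc(C)nc(N)c12`; the two have the same atoms joined differently, and the difference between the two cores is not broken down here. Compound 3 is `Cc1nc(N)c2c(I)cn([C@@H]3O[C@H](CO)[C@@H](O)[C@H]3O)c2n1` and compound 4, not yet measured, is `CNc1ncnc2c1c(I)cn2[C@@H]1O[C@H](CO)[C@@H](O)[C@H]1O`.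

In an ADME assay on MRC5 cells (Homo sapiens), read by MTT assay, with a stated time of 72 h (a lower number here means a stronger inhibitor, a higher number a weaker inhibitor), compound 1 reaches only the limit of the assay, > 100000 nM. Compound 2 likewise gives only the limit > 100000 nM in this assay. Compound 3 gives a number in this assay, 85800 nM.

From compound 2 to compound 3 the change is iodo in place of ethynyl on an aromatic carbon, and in this assay the step is an at least 1.1-fold lower number from compound 2 to compound 3 (0.06 log units; that floor lies within the scatter). From compound 1 to compound 4 the change is iodo in place of ethynyl on an aromatic carbon, the same change at the same place. Because (the limit of > 100000 nM in this assay, at which 2 of the 3 values shown sit), the measured step only tells that compound 3 sits close to where compound 2 stopped. For compound 4 the step from compound 1 is expected to be small as well, an at least 1.0-fold lower number from compound 1 to compound 4 (0.02 log units; that floor lies within the scatter), resting on that single measured pair. Compound 4 is therefore expected to give about 95000 nM in this assay, anywhere from 45000 nM to 200000 nM, with a fair chance that only a limit is reported again.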

Compound 4, half-maximal inhibitory concentration: > 100000 nM
Compound 4: a limit, no number; the forecaster's own chance of this, stated with the estimate: 50%; middle value at least 1.0-fold (0.02 log units) from the limit.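

Compound 1 and compound 4 both give only a limit in this assay, so no size can be read for the step between them, iodo in place of ethynyl on an aromatic carbon, because neither has a number: the limit of > 100000 nM in this assay, at which 3 of the 4 values shown sit.

The compounds shown leave open whether this change alters the result at all on the core of compound 1, and how compound 2 truly compares with compound 3.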